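Three Hydrazones Measured, a Fourth Awaiting Its Number

This account rests on a few compounds, and the source may have more. Where it says the series, first, only, none or still open, it means among the compounds named here.

Three compounds have so far been measured in a functional assay on HepG2 cells (Homo sapiens) for inhibition, read by MTT assay, with a stated time of 72 h; on this read-out lower numbers stand for stronger inhibition and higher numbers for weaker inhibition:

- Compound 1 `CN(C(=O)NC(=O)c1ccc(F)c(F)c1)c1nc(C(F)(F)F)c(C(=O)N/N=C/c2cccc(C(F)(F)F)c2)s1` gives 5.6 ug/mL
- Compound 2 `CN(C(=O)NC(=O)c1ccc(F)c(F)c1)c1nc(C(F)(F)F)c(C(=O)N/N=C/c2cc(C(F)(F)F)cc(C(F)(F)F)c2)s1` gives 5.47 ug/mL
- Compound 3 `CN(C(=O)NC(=O)c1ccc(F)c(F)c1)c1nc(C(F)(F)F)c(C(=O)N/N=C/c2ccccc2C(F)(F)F)s1` gives 10.4 ug/mL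

Compound 2 holds the lowest of the three numbers, but its nearest neighbour is compound 1 and the step of a 1.0-fold lower number from compound 1 to compound 2 (0.01 log units; within the scatter) lies within the scatter, as does the step of a 1.9-fold higher number from compound 1 to compound 3 (0.27 log units; within the scatter); nothing in this set separates any compound from the others beyond repeat-measurement noise.

Compound 4 `CN(C(=O)NC(=O)c1ccc(C(F)(F)F)cc1)c1nc(C(F)(F)F)c(C(=O)N/N=C/c2cc(C(F)(F)F)cc(C(F)(F)F)c2)s1` is the next compound to be tested. It differs from compound 2 in this way: 4-(trifluoromethyl)phenyl in place of 3,4-difluorophenyl on a carbonyl carbon

Among the compounds with values here, both measured steps concern the aryl group bound to the carbon with a double bond to nitrogen; neither touches the carbonyl carbon where compound 4 differs from compound 2, so no measured step bears directly on this change. Given that every step seen so far in this assay stayed within the scatter, compound 4 is expected to land near compound 2, with the step of a 1.0-fold higher number from compound 2 to compound 4 (0.00 log units; within the scatter) estimated to be small in either direction. Compound 4 is therefore estimated at 5.5 ug/mL, within a range of 2.5 ug/mL to 12 ug/mL.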

Compound 4, half-maximal inhibitory concentration: 8.35 ug/mL
Beside the measured number, compound 4's estimate is 1.5-fold (0.18 log units) below it; low and high end bracket the measured number.
By their numbers in this assay, from the lowest: compounds 2, 1, 4 and 3 (each within the scatter of the next).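

This first reading at the carbonyl carbon, in this assay, shows that the exchange of 3,4-difluorophenyl for 4-(trifluoromethyl)phenyl gives a 1.5-fold higher number from compound 2 to compound 4 (0.18 log units; within the scatter) and so stays inside what repeat measurements would allow. The earlier compounds shown here all carried the same 3,4-difluorophenyl there, so they could say nothing about this position, whereas here an entering group of 10 heavy atoms replaces one of 8 with no step beyond the scatter. No measurement shown offers an explanation for this result.

The compounds shown leave open how this position responds to anything other than these two substituted phenyl groups, such as a phenyl ring bearing an amine or a carboxylic acid, or a plain butyl chain. Going by these compounds, it also remains open whether the same exchange reads alike with the aryl groups of compound 1 or compound 3 on the carbon with a double bond to nitrogen.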